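A few compounds are considered here, and "the series" means these few. Any claim that something is new, unique, unknown or untested is made for them only; others in the source may bear on it.

Compound 1 `COc1ccc(-c2cccc(COc3ccc([C@H](CC(=O)O)c4nccn4C)cc3)c2)cc1`: "not determined" (no result reported) in an assay on CHO cells for agonist activity at Free fatty acid receptor 1 (Homo sapiens), read by luminescence, with a stated time of 20 s, in the presence of a further agent that is not named here; a lower number here means that less compound is needed, a higher number that more compound is needed for the effect
Compound 2 `Cc1cc(Cl)ccc1-c1cccc(COc2ccc([C@H](CC(=O)O)c3nccn3C)cc2)c1`: 10000 nM

Compound 2 stands alone on the numbers shown: it is the only compound with a value in this assay, and compound 1 gives no number at all, so there is nothing to compare it with. Its value is weak on this scale, and a change of moderate size in either direction would still leave it among weak agonists.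

Compound 3 `Cc1cc(Cl)ccc1-c1cccc(COc2ccc([C@H](CC(=O)O)c3nccn3C)cc2)c1C` differs from compound 2 by a single change: methyl in place of hydrogen on an aromatic carbon. Within the data shown here, no pair of measured compounds shows what such a change does here, so the expected size of the step rests on the change alone. Compound 3 is expected at 3000 nM (range 500 nM to 20000 nM), meaning an estimated step of a 3.3-fold lower number from compound 2 to compound 3 (0.52 log units; beyond the scatter) that may well stay within the scatter.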

Compound 3, half-maximal effective concentration: 23000 nM
Compound 3: middle estimate off by 7.7-fold (0.88 log units), on the low side; the measured number lies above the stated range.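

In this assay, among these compounds, methyl in place of hydrogen on this aromatic carbon, ortho to a 4-chloro-2-methylphenyl group, gives a 2.3-fold higher number from compound 2 to compound 3 (0.36 log units; beyond the scatter), the first measured step at this position. The step is modest, but it runs toward a higher number, so in this pair the added methyl means more compound is needed, starting from a compound that was already weak on this scale. Nothing in the information given accounts for this step.

Going by these compounds, whether a fluorine, a hydroxyl or an amine on the same carbon would move the number in the same direction remains open. On these data alone, it is also open whether methyl at this position would have the same effect if another group stood in place of the 4-chloro-2-methylphenyl group.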